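Moving from trifluoromethyl to chlorine on the urea aryl group

A few compounds are considered here, and "the series" means these few. Any claim that something is new, unique, unknown or untested is made for them only; others in the source may bear on it.

Compound 2 `O=C(NCCCOc1cccc(CN2CCCCC2)c1)Nc1ccc(C(F)(F)F)cc1` stands highest of the two numbers in an assay on isolated protein for inhibition of histamine H2 receptor (Cavia porcellus) (a higher number here means weaker binding, a lower number tighter binding), with 1700 nM. Its neighbour compound 1 `O=C(NCCCOc1cccc(CN2CCCCC2)c1)Nc1ccccc1` gives 126 nM in this assay. Compound 3 `O=C(NCCCOc1cccc(CN2CCCCC2)c1)Nc1cccc(Cl)c1` differs from compound 2 by 3-chlorophenyl in place of 4-(trifluoromethyl)phenyl on an amide-type nitrogen. Going by the values given here, only one measured step bears on this: a 13-fold higher number from compound 1 to compound 2 (1.13 log units; beyond the scatter). Since the change to compound 3 swaps one substituted ring for another rather than returning to bare phenyl, a partial reversal is expected, giving a 5.7-fold lower number from compound 2 to compound 3 (0.75 log units; beyond the scatter). Compound 3 is therefore estimated at 300 nM in this assay, within a range of 100 nM to 1000 nM.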

Compound 3, dissociation constant: 316 nM
The estimate for compound 3 lay 1.1-fold (0.02 log units) below the measured number, within the range that was stated.
By their numbers in this assay, from the lowest: compound 1; then compound 3; then compound 2.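

Swapping 4-(trifluoromethyl)phenyl for 3-chlorophenyl on an amide-type nitrogen gives a 5.4-fold lower number from compound 2 to compound 3 (0.73 log units; beyond the scatter) in this assay, so this position does not respond to every substituted ring alike. Chloro in place of hydrogen still gives a 2.5-fold higher number from compound 1 to compound 3 (0.40 log units; beyond the scatter), leaving both substituted rings shown with higher numbers than the bare phenyl ring. Nothing available accounts for these differences.

The two substituted rings differ in both the group and where it sits, so the compounds shown do not separate these two changes. On these data alone, whether a methoxy group or an amine on this ring would bring the number closer to that of compound 1 stays open.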